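Compound 2 to compound 3: a sulfonyl swap

The source may report more compounds than this note shows. Statements on the series, on what has been measured and on what is new or still open speak of the compounds shown alone.

In a functional assay on HepG2 cells (Homo sapiens) for cytotoxicity, read by MTT assay (a higher number here means a weaker inhibitor, a lower number a stronger inhibitor), compound 1 (`CCC(=O)Oc1cc(/C=C/C(=O)c2ccc(OC)c3c2OC(C)(C)C=C3)ccc1OC`) gives 90 nM and compound 2 (`COc1ccc(/C=C/C(=O)Oc2cc(/C=C/C(=O)c3ccc(OC)c4c3OC(C)(C)C=C4)ccc2OC)cc1`) gives 430 nM as the higher of the two numbers, so compound 2 is the weaker inhibitor. Compound 3 (`COc1ccc(/C=C/C(=O)c2ccc(OC)c3c2OC(C)(C)C=C3)cc1OS(=O)(=O)c1ccc(C)cc1`) has (4-methylphenyl)sulfonyl in place of (2-(4-methoxyphenyl)ethenyl)carbonyl on an oxygen on an aromatic ring. For the measured compounds named here, the only measured change on that oxygen (a 4.8-fold higher number from compound 1 to compound 2 (0.68 log units; beyond the scatter)) was modest and brought in the group now leaving. Going by the values given here, no sulfonyl compound has been measured, so only a modest step to a lower number is expected (a 2.4-fold lower number from compound 2 to compound 3 (0.38 log units; beyond the scatter)). For compound 3 the estimate is 180 nM with an expected range (50 nM to 600 nM).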

Compound 3, half-maximal inhibitory concentration: 3600 nM
Beside the measured number, compound 3's estimate is 20-fold (1.30 log units) below it; measured number outside the range, above it.
By their numbers in this assay, from the lowest: compound 1; then compound 2; then compound 3.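

For the compounds shown here, on an oxygen on an aromatic ring, in this assay, (4-methylphenyl)sulfonyl gives the highest number so far, with an 8.4-fold higher number from compound 2 to compound 3 (0.92 log units; beyond the scatter) and a 40-fold higher number from compound 1 to compound 3 (1.60 log units; beyond the scatter). Compound 1 and compound 2 alone suggested that a larger group raises the number, but compound 3 goes against this: its group has fewer heavy atoms than the (2-(4-methoxyphenyl)ethenyl)carbonyl it replaces. No measurement at hand explains this rise. As far as these compounds go, it remains open whether the sulfonyl link or the 4-methylphenyl ring drives the rise. A methanesulfonyl group or a free hydroxyl on that oxygen could help separate these possibilities.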